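Notes on a hydroxymethyl step from compound 2

The source may report more compounds than this note shows. Statements on the series, on what has been measured and on what is new or still open speak of the compounds shown alone.

Of the compounds shown here, two carry numbers so far. In a functional assay for inhibition, with Homo sapiens as the target (on this read-out higher numbers stand for weaker inhibition and lower numbers for stronger inhibition), compound 1 `COc1ccc(O)c(CCc2ccccc2)c1` gives 120 nM, and compound 2 `COc1ccc(O)c(CSc2ccccc2)c1` gives 590 nM. Compound 2 therefore holds the higher of the two numbers, which here means the weaker inhibition, and its gap to compound 1 lies beyond the usual scatter.

The next compound is compound 3 `COc1ccc(O)c(CSc2ccccc2CO)c1`. It differs from compound 2 in one place: hydroxymethyl in place of hydrogen on an aromatic carbon, with hydroxymethyl in place of hydrogen on an aromatic carbon, ortho to a large group.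

For the measured compounds named here, no measured pair shows what such a substitution does, so the expectation starts from compound 2 at 590 nM and stays wide. In this assay only a small shift toward weaker inhibition is expected, and it may well not exceed the scatter. The estimated change is a 1.2-fold higher number from compound 2 to compound 3 (0.07 log units; within the scatter). For compound 3 the expected value is 700 nM, with an estimated range from 200 nM to 2500 nM.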

Compound 3, half-maximal inhibitory concentration in the Homo sapiens assay: 8700 nM
Compound 3: the middle estimate sits 12-fold (1.09 log units) below what was measured, and the stated range ends below it.
By their numbers in the Homo sapiens assay, from the lowest: compound 1; then compound 2; then compound 3.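

In the Homo sapiens assay, hydroxymethyl in place of hydrogen on an aromatic carbon, ortho to a large group, gives the first step read at this place on the ring: a 15-fold higher number from compound 2 to compound 3 (1.17 log units; beyond the scatter). The place is therefore not neutral toward substitution, at least for this group, and the step is large enough to take compound 3 well past both earlier compounds toward weaker inhibition. In a physicochemical assay for lipophilicity (on this read-out lower numbers stand for lower lipophilicity and higher numbers for higher lipophilicity), compound 2 gives 3.9, and compound 3 gives 2.9. The loss in inhibition comes together with lower lipophilicity in the physicochemical assay, which shows the two read-outs moving in opposite senses across this one step, though a single pair cannot tie one shift to the other: the measured partition coefficient of compound 2, 3.9, and of compound 3, 2.9, a number 1.00 log units lower (beyond the scatter).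

Still open, as far as these compounds go, is whether the loss belongs to hydroxymethyl itself or to any group at this place, which a methyl, a methoxy or an amine there could separate, with a methyl group also testing whether the loss follows without the hydroxyl. Also open, from the compounds shown here alone, is whether the same substitution would cost as much on the core of compound 1, which carries a carbon link in place of the sulfur of compound 2.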